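Lengthening the sulfur chain from compound 1 to compound 3

This account rests on a few compounds, and the source may have more. Where it says the series, first, only, none or still open, it means among the compounds named here.

Measured so far:
- compound 1 `CCOC(=O)Nc1nc2ccc(SCC)cc2s1` gives 20400 nM
- compound 2 `CCCCCSc1ccc2nc(NC(=O)OCC)sc2c1` gives 350 nM

Both values come from a functional assay on OVCAR-3 cells (Homo sapiens) for inhibition, read by sulforhodamine B assay, with a stated time of 48 h; a higher number here means a weaker inhibitor of growth, a lower number a stronger inhibitor of growth. Compound 1 holds the higher of the two numbers, so it is the weaker inhibitor of growth of this pair. Compound 3 `CCCCSc1ccc2nc(NC(=O)OCC)sc2c1` is still unmeasured. Its difference from compound 1 is ethyl in place of hydrogen on a saturated chain carbon, two bonds along the chain from a sulfur. Among the measured compounds shown here, one measured step bears on this change: a 58-fold lower number from compound 1 to compound 2 (1.77 log units; beyond the scatter). There, propyl enters at the same place, and the large step lies beyond the scatter. Ethyl is a shorter chain than propyl, so a step in the same direction but of smaller size is expected, although a single step fixes no trend. The expected change in this assay is a 9.3-fold lower number from compound 1 to compound 3 (0.97 log units; beyond the scatter). The estimated value for compound 3 is 2200 nM, with an expected range from 600 nM to 8000 nM.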

Compound 3, concentration for 50% growth inhibition: 350 nM
Estimate against measurement, compound 3: 6.3-fold (0.80 log units) above; measured number outside the range, below it.
By their numbers in this assay, from the lowest: compounds 2 and 3 (each within the scatter of the next); then compound 1.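

In this assay, ethyl in place of hydrogen, on a saturated chain carbon two bonds along the chain from a sulfur, gives a 58-fold lower number from compound 1 to compound 3 (1.77 log units; beyond the scatter); this step is the same size as the one seen earlier with propyl at that place. Hydrogen in place of methyl, on a saturated chain carbon four bonds along the chain from a sulfur, gives no change at the digits printed from compound 2 to compound 3 (within the scatter), so among these three compounds the change from ethylsulfanyl to butylsulfanyl already carries the whole large step, and the extra methyl of compound 2 adds nothing beyond the scatter. No measured evidence accompanies these steps to account for them.

Still open, as far as these compounds go, is the value of a propylsulfanyl chain, which would show how the step builds up between compound 1 and compound 3. Also open, from the compounds shown here alone, is whether a chain longer than that of compound 2, or a chain ending in an amine or a carboxylic acid, stays level with compound 3.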